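This account rests on a few compounds, and the source may have more. Where it says the series, first, only, none or still open, it means among the compounds named here.

Series notes: the shared core of compound 1 `O=S(=O)(Nc1ccc2oc(-c3ccccc3)nc2c1)c1ccc(Cl)cc1` carries a sulfonamide on its benzoxazole-free description — the core is as drawn. In an ADME assay on HEK293 cells (Homo sapiens) for cytotoxicity, read by resazurin assay, with a stated time of 48 h (on this read-out lower numbers stand for higher toxicity in this test and higher numbers for lower toxicity in this test), compound 1 gives 65000 nM; compound 2 `O=S(=O)(Nc1ccc2oc(-c3ccccc3)nc2c1)c1ccc(Cl)c(C(F)(F)F)c1` gives 66000 nM and compound 3 `O=S(=O)(Nc1ccc2oc(-c3ccccc3)nc2c1)c1ccc(C(F)(F)F)cc1` gives 74000 nM, so all three numbers sit within the scatter of one another and compound 1 is not set apart from either.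

Compound 4 `CS(=O)(=O)Nc1ccc2oc(-c3ccccc3)nc2c1` differs from compound 1 by methyl in place of 4-chlorophenyl on a sulfonyl sulfur. The two measured steps, a 1.0-fold higher number from compound 1 to compound 2 (0.01 log units; within the scatter) and a 1.1-fold higher number from compound 1 to compound 3 (0.06 log units; within the scatter), alter substituents on the arene that leaves here; neither moved the number beyond the scatter. Among the measured compounds shown here, they bear on the step to compound 4 only indirectly, since the whole arene is exchanged for methyl, and no measured step covers that exchange. Given the flat picture across compounds 1, 2 and 3, no step beyond the scatter is expected, with the range widened for the untested exchange: the expected step is a 1.1-fold higher number from compound 1 to compound 4 (0.03 log units; within the scatter). Compound 4 is therefore estimated at 70000 nM, between 30000 nM and 160000 nM.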

Compound 4, half-maximal cytotoxic concentration: > 100000 nM
Compound 4: no number, only a limit; the forecaster's own chance of this, stated with the estimate: 25%; middle value at least 1.4-fold (0.15 log units) from the limit.
By their numbers in this assay, from the lowest: compounds 1, 2 and 3 (each within the scatter of the next). At a limit, above all of these: compound 4.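

At the sulfonyl sulfur, methyl in place of 4-chlorophenyl gives in this assay an at least 1.5-fold higher number from compound 1 to compound 4 (0.18 log units; that floor lies within the scatter). Compounds 2 and 3 changed only substituents on the arene, whereas this change removes the whole arene, and the number does not fall, so the 4-chlorophenyl group is not required to keep the number at this level. The reading for compound 4 is a limit of the assay and not a number, so the full size of the step stays unknown and it cannot be placed beyond the scatter: the limit of > 100000 nM in this assay, at which 1 of the 4 values shown sits.

On these data alone, it remains open whether a longer chain, such as ethyl or butyl, would read like methyl at this sulfur. The same applies to a sulfonyl sulfur carrying an amine, or a saturated ring such as cyclohexyl.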